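Nitro to hydrogen: opening notes on compound 1 and compound 3

The compounds below may be only part of what the source reports. "The series", "measured", "known", "first", "only" and "open" are said of these compounds alone.

Working notes on the series. The read-out throughout is a functional assay on the whole organism with Mus musculus as the target; on this read-out lower numbers stand for an effect already at smaller amounts and higher numbers for an effect only at larger amounts of compound. Compound 1, `COc1cc2c(cc1OC)C(c1ccc([N+](=O)[O-])cc1)=NNC(=O)C2`, stands at a limit in this assay and not at a number: compound 1 gives > 120 umol/kg. Its place in the series is therefore fixed only by the limit of > 120 umol/kg in this assay, at which 1 of the 2 values shown sits. The other measured member is compound 2, `COc1cc2c(cc1OC)C(c1ccc(Br)cc1)=NN(C)C(=S)C2`; in this assay compound 2 gives 105 umol/kg. For the measured compounds named here, compound 1 and compound 2 differ in more than one place, so no single step joins them; their two values show only that one is a limit and the other a number in the same region.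

The next member is compound 3, `COc1cc2c(cc1OC)C(c1ccccc1)=NNC(=O)C2`, not yet measured. Its change from compound 1 is hydrogen in place of nitro on an aromatic carbon. Going by the values given here, no measured step of this kind exists, so the size of the move is open. With compound 1 at a limit, the expected step is a number no higher from compound 1 to compound 3 (the limit leaves the size open), which is taken as no step beyond the scatter. Compound 3 is estimated at 120 umol/kg, within 50 umol/kg to 300 umol/kg, with a real chance that this assay again returns only a limit.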

Compound 3, dose for half-maximal effect: 33.9 umol/kg
Compound 3: the middle estimate sits 3.5-fold (0.55 log units) above what was measured; the measured number lies below the stated range.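

Hydrogen in place of nitro on an aromatic carbon, para to a large group, gives in this assay an at least 3.5-fold lower number from compound 1 to compound 3 (0.54 log units; beyond the scatter), and this is the only single-place step in the series so far. It shows that what sits at this position on the six-membered aromatic ring of carbon matters to the read-out in the whole mouse, which compound 1 and compound 2 could not show, as they differ in more than one place. The direction of the step is fixed, but its full size is not, because compound 1 stands at a limit and gives only a lower bound on the step: the limit of > 120 umol/kg in this assay, at which 1 of the 3 values shown sits.

A single step from nitro to hydrogen cannot tell whether nitro in particular holds the number up or whether any group at this position would do the same, and an amine, a methoxy group or a chlorine there would begin to separate the two readings. Going by these compounds, compound 2 carries bromine on this ring but differs from compound 3 in more than one place, so the effect of a halogen at this position remains open.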